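Swapping Pyrrolidin-1-yl for Benzylsulfanyl on a Shared Core

The source may report more compounds than this note shows. Statements on the series, on what has been measured and on what is new or still open speak of the compounds shown alone.

Three compounds built on one core have been examined in an ADME assay on Akata cells (Homo sapiens) for cytotoxicity, with a stated time of 7 days; a lower number here means that less compound is tolerated, a higher number that more compound is tolerated. Compound 1 `CNc1nc(N)nc2c1ncn2/C=C1/CC1(CO)CO` carries a methylamino group on the core. In this assay compound 1 gives only a limit of > 24000 nM. Compound 2 `Nc1nc(N2CCCC2)c2ncn(/C=C3/CC3(CO)CO)c2n1` carries pyrrolidin-1-yl in place of methylamino. In this assay compound 2 likewise gives only a limit of > 24000 nM. Compound 3 `CCCCCOc1nc(N)nc2c1ncn2/C=C1/CC1(CO)CO` carries pentyloxy on that carbon. In this assay compound 3 gives a limit of > 20000 nM. Compound 2 therefore stands among values that are all limits, namely the limit of > 24000 nM in this assay, at which 2 of the 3 values shown sit, and (the limit of > 20000 nM in this assay, at which 1 of the 3 values shown sits). The steps a step that the two limits leave unreadable from compound 1 to compound 2 and a step that the two limits leave unreadable from compound 2 to compound 3 are of unreadable size, and so is a step that the two limits leave unreadable from compound 1 to compound 3.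

Compound 4 `Nc1nc(SCc2ccccc2)c2ncn(/C=C3/CC3(CO)CO)c2n1` differs from compound 2 in one place: benzylsulfanyl in place of pyrrolidin-1-yl on an aromatic carbon. Among the compounds with values here, none of the measured steps has a readable size, so the expectation for compound 4 rests on the three limits alone and on the fact that no change of the group at this position has yet produced a number inside the measurable range. Compound 4 is expected to sit at about 30000 nM, in a range from 12000 nM to 90000 nM. This corresponds to an estimated step that the limit leaves unreadable from compound 2 to compound 4, which is expected to be none beyond the scatter.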

Compound 4, half-maximal cytotoxic concentration: > 20000 nM
Compound 4 ended at the assay's limit; the forecaster's own chance of this, stated with the estimate: 75%; the middle value lies beyond the limit too.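

In this assay, within the data shown here, compound 4 gives only a limit, as do compound 1, compound 2 and compound 3, so no step between compound 4 and any of them can be read. The compounds shown leave open whether exchanging these groups on the shared core changes the cytotoxic concentration at all.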